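A Methyl in Place of Hydrogen on the Phenyl of Compound 1

A few compounds are considered here, and "the series" means these few. Any claim that something is new, unique, unknown or untested is made for them only; others in the source may bear on it.

Compound 1 `c1ccc(CNC(c2ccc[nH]2)c2nnc(-c3ccccc3)o2)cc1` gives 231000 nM in a functional assay on HT-1080 cells (Homo sapiens) for cytotoxicity, read by MTT assay, with a stated time of 24 h (on this read-out higher numbers stand for weaker inhibition and lower numbers for stronger inhibition), the highest of the three numbers recorded for this series. Compound 2 `Clc1ccc(-c2nnc(C(NCc3ccccc3)c3ccc[nH]3)o2)cc1` gives 41000 nM, and compound 3 `Brc1ccc(-c2nnc(C(NCc3ccccc3)c3ccc[nH]3)o2)cc1` gives 70600 nM. The steps of a 5.6-fold lower number from compound 1 to compound 2 (0.75 log units; beyond the scatter) and a 3.3-fold lower number from compound 1 to compound 3 (0.51 log units; beyond the scatter) show that a halogen on the phenyl lowers the number modestly, while the step of a 1.7-fold higher number from compound 2 to compound 3 (0.24 log units; within the scatter) stays within the scatter. Compound 4 `Cc1cccc(-c2nnc(C(NCc3ccccc3)c3ccc[nH]3)o2)c1` differs from compound 1 by methyl in place of hydrogen on an aromatic carbon. A methyl is not a halogen, so those two steps bear only loosely on this one; a step in the same direction but smaller than either is expected. Compound 4 is therefore estimated at 110000 nM, between 45000 nM and 260000 nM, which amounts to an expected 2.1-fold lower number from compound 1 to compound 4 (0.32 log units; beyond the scatter).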

Compound 4, half-maximal inhibitory concentration: 311000 nM
For compound 4 the middle estimate is 2.8-fold (0.45 log units) below the measured one; measured number above the stated range.
By their numbers in this assay, from the lowest: compounds 2 and 3 (each within the scatter of the next); then compounds 1 and 4 (each within the scatter of the next).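

In this assay, methyl on this phenyl gives a 1.3-fold higher number from compound 1 to compound 4 (0.13 log units; within the scatter), so unlike chloro and bromo it does not separate from the unsubstituted compound. The steps of a 4.4-fold higher number from compound 3 to compound 4 (0.64 log units; beyond the scatter) and a 7.6-fold higher number from compound 2 to compound 4 (0.88 log units; beyond the scatter) change both the group and its place on the ring, and they show that a substituent on this phenyl does not by itself lower the number. Nothing available explains this difference. Still open, going by these compounds, is whether the gap follows the group or its place on the ring, and what a methoxy group or an amine on this phenyl would do.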